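The source may report more compounds than this note shows. Statements on the series, on what has been measured and on what is new or still open speak of the compounds shown alone.

Measured in a functional assay on HeLa cells (Homo sapiens) for inhibition; a higher number here means a weaker inhibitor of growth, a lower number a stronger inhibitor of growth:
- Compound 1 `COC(=O)c1ccsc1NC(=O)[C@@H]1CCCN1` gives > 250 ug/mL (a limit of the assay, not a number)
- Compound 2 `CCOC(=O)c1ccsc1NC(=O)[C@@H]1CCCN1` gives 35.3 ug/mL (a number)
- Compound 3 `O=C(OC1CCCCC1)c1ccsc1NC(=O)[C@@H]1CCCN1` gives 92.8 ug/mL (a number)

Of the two numbers obtained, the higher belongs to compound 3 at 92.8 ug/mL and the lower to compound 2. The value of compound 1 remains a limit.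

Compound 4 `C=CCOC(=O)c1ccsc1NC(=O)[C@@H]1CCCN1` has not yet been measured. It differs from compound 3 by allyl in place of cyclohexyl on an oxygen next to a carbonyl group. The closest guide is the ethyl ester, compound 2, since ethyl is also an open chain. Cyclohexyl in place of ethyl gave a 2.6-fold higher number from compound 2 to compound 3 (0.42 log units; beyond the scatter) in this assay and is a modest change. The steps of an at least 7.0-fold lower number from compound 1 to compound 2 (0.85 log units; beyond the scatter) and an at least 2.6-fold lower number from compound 1 to compound 3 (0.43 log units; beyond the scatter) rest on a limit, so they show only that methyl stands apart. Removing the cyclohexyl is therefore expected to give a modest move to a lower number, close to compound 2. The expected step is a 2.1-fold lower number from compound 3 to compound 4 (0.31 log units; beyond the scatter) in this assay. For compound 4 the estimated value is 45 ug/mL, with an expected range from 15 ug/mL to 130 ug/mL.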

Compound 4, concentration for 50% growth inhibition: 94.9 ug/mL
Compound 4: the middle estimate sits 2.1-fold (0.32 log units) below what was measured; measured number inside the range.
By their numbers in this assay, from the lowest: compound 2; then compounds 3 and 4 (each within the scatter of the next). At a limit, above all of these: compound 1.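

In this assay, allyl in place of cyclohexyl gives a 1.0-fold higher number from compound 3 to compound 4 (0.01 log units; within the scatter), so an open chain on this oxygen is not enough by itself to match compound 2. Vinyl in place of methyl on the saturated chain carbon gives a 2.7-fold higher number from compound 2 to compound 4 (0.43 log units; beyond the scatter), which makes compound 2 the strongest inhibitor of the four and shows that a small change to the ethyl group is enough to move the number. Compound 1 stays at a limit of the assay, not a number, so an at least 2.6-fold lower number from compound 1 to compound 4 (0.42 log units; beyond the scatter) reads only as a bound: the limit of > 250 ug/mL in this assay, at which 1 of the 4 values shown sits.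

The compounds shown leave open whether the double bond matters, which a propyl ester would test. They also leave open whether the ester is needed at all, which a carboxylic acid or an amide in its place would test.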